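A few compounds are considered here, and "the series" means these few. Any claim that something is new, unique, unknown or untested is made for them only; others in the source may bear on it.

Measured so far in an assay on microsomes for inhibition of acyl-CoA:cholesterol acyltransferase (Oryctolagus cuniculus); a lower number here means a stronger inhibitor, a higher number a weaker inhibitor:

compound 1, `CC(C)c1ccc(C2(CNC(=O)Nc3c(C(C)C)cccc3C(C)C)CCCC2)cc1`, 48 nM
compound 2, `CC(C)c1cccc(C(C)C)c1NC(=O)NCC1(c2ccc(OCc3ccccc3)cc2)CCCC1`, 34 nM
compound 3, `CC(C)c1cccc(C(C)C)c1NC(=O)NCC1(c2cccc([N+](=O)[O-])c2)CCCC1`, 51 nM

All three numbers lie close together: a 1.4-fold lower number from compound 1 to compound 2 (0.15 log units; within the scatter) and a 1.1-fold higher number from compound 1 to compound 3 (0.03 log units; within the scatter). Compound 1 therefore sits among the others with no gap beyond the scatter on either side, and nothing in the set so far can be called stronger or weaker than the rest.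

Compound 4, `CC(C)c1cccc(C(C)C)c1NC(=O)NCC1(c2ccc(N)cc2)CCCC1`, differs from compound 1 in one place: amino in place of isopropyl on an aromatic carbon. For the measured compounds named here, the only measured change at that same aromatic carbon is the one from compound 1 to compound 2, benzyloxy in place of isopropyl, which gave a 1.4-fold lower number from compound 1 to compound 2 (0.15 log units; within the scatter). The other measured step, a 1.1-fold higher number from compound 1 to compound 3 (0.03 log units; within the scatter), replaces the whole aryl group on the saturated ring carbon and also stayed within the scatter. Going by the values given here, no measured compound in this set carries an amino group, so the step to compound 4 rests on an analogy of position only, not of group. On that basis the expectation is for no step beyond the scatter, with a 1.4-fold higher number from compound 1 to compound 4 (0.13 log units; within the scatter) taken as the estimate, and a wide range to reflect the thin support. Compound 4 is thus expected to give 65 nM in this assay, with a range from 25 nM to 170 nM.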

Compound 4, half-maximal inhibitory concentration: 29 nM
Compound 4: the middle estimate sits 2.2-fold (0.35 log units) above what was measured; low and high end bracket the measured number.
By their numbers in this assay, from the lowest: compounds 4, 2, 1 and 3 (each within the scatter of the next).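

Across this assay, the aromatic carbon para to a large group now tolerates amino as well as isopropyl and benzyloxy: a 1.7-fold lower number from compound 1 to compound 4 (0.22 log units; within the scatter), and a 1.2-fold lower number from compound 2 to compound 4 (0.07 log units; within the scatter), so going from 3 heavy atoms to 1 heavy atom and bringing in a hydrogen-bond donor and a hydrogen-bond acceptor produces no step beyond the scatter at this position. The whole aryl group tells the same story, with a 1.8-fold lower number from compound 3 to compound 4 (0.25 log units; within the scatter), where 4-aminophenyl stands in place of 3-nitrophenyl on the saturated ring carbon and the step again stays within the scatter. Nothing measured on these compounds bears on why the number holds across these changes.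

Going by these compounds, the four compounds therefore give no group at this aromatic carbon that separates from the others, and it stays open whether a carboxylic acid or a dimethylamino group there would produce a step beyond the scatter. Also open, on these data alone, is whether the flat picture holds for changes elsewhere in the shared core, such as a longer chain in place of one isopropyl group.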